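The source may hold more compounds than are shown below. What is called first, only, known or untested is meant among the compounds shown, and "the series" means these compounds.

Working notes on the series. The shared core is that of compound 1 `CC1=C(C(=O)Nc2ccc(Br)cc2)C(c2ccc(Cl)cc2Cl)N=C(SCc2ccccc2)N1`; compound 2 `COc1ccc(C2N=C(SCc3ccccc3)NC(C)=C2C(=O)Nc2ccc(Br)cc2)cc1` and compound 3 `CC1=C(C(=O)Nc2ccc([N+](=O)[O-])cc2)C(c2ccc(Br)cc2)N=C(SCc2ccccc2Cl)N1` are the other measured members, and compound 4 `CC1=C(C(=O)Nc2ccc([N+](=O)[O-])cc2)C(c2ccc(Br)cc2)N=C(SCc2ccc(Cl)cc2)N1` is still to be measured. In a functional assay on the whole organism (artery, strain albino) with Rattus norvegicus as the target, with a stated time of 60 min, at a dose of 10 mg/kg by the oral route (on this read-out lower numbers stand for less inhibition and higher numbers for more inhibition at the one dose given (going by the name of the read-out)), compound 1 gives 6.7%, compound 2 gives 5.6% and compound 3 gives 6.7%. On these numbers compound 3 stands level with compound 1 at the digits printed, and the number for compound 2 lies within the scatter of both. Among the compounds with values here, the one measured step, a number 1.1 percentage points lower from compound 1 to compound 2 (within the scatter), concerns a different place in the molecule and stays within the scatter. Compound 4 differs from compound 3 by 4-chlorophenyl in place of 2-chlorophenyl on a saturated chain carbon bound to a sulfur. Within the data shown here, no measured step touches this place, so the data give no support for a change beyond the scatter in this assay from this exchange. Compound 4 is therefore expected to show no change at the digits printed from compound 3 to compound 4 (within the scatter), which amounts to no change beyond the scatter. The estimate for compound 4 in this assay is 6.7%, with a range from 0% to 16%.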

Compound 4, a percentage reported as inhibition, in the whole organism at one dose (the size of the read-out at that dose, not a potency): 10.8%
Compound 4: the middle estimate sits 4.1 percentage points below what was measured; measured number inside the range.
By their numbers in this assay, from the lowest: compounds 2, 1, 3 and 4 (each within the scatter of the next).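

This place on a saturated chain carbon bound to a sulfur now has its first measured step: in this assay, the exchange of 2-chlorobenzyl for 4-chlorobenzyl gives a number 4.1 percentage points higher from compound 3 to compound 4 (within the scatter). The change of chlorine position on this phenyl ring therefore does not separate the two compounds on this read-out, and all four members of the series remain within the scatter of their neighbours in the ranking. No measured information is available to explain the size of this step.

Going by these compounds, what a 2-phenylethyl chain, or a carboxylic acid or an amine on the phenyl ring, would give at this place remains open. Also open, on these data alone, is whether the same chlorine exchange would read the same way with the other groups on the shared core.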